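Phenyl in place of methyl carried across two cores

The source may hold more compounds than are shown below. What is called first, only, known or untested is meant among the compounds shown, and "the series" means these compounds.

Compound 1 `Cc1cc2c(c(N)nn2C)c(=O)[nH]1` gives 2% in an assay on isolated protein for inhibition of ribosomal protein S6 kinase alpha-1 (Homo sapiens), read by mobility shift assay, tested at 30 uM; on this read-out lower numbers stand for less inhibition and higher numbers for more inhibition at the one concentration tested (going by the name of the read-out). Compound 2 `Cn1nc(N)c2c(=O)[nH]c(-c3ccccc3)cc21` differs from it by phenyl in place of methyl on an aromatic carbon and gives 8% in this assay; the step of a number 6 percentage points higher from compound 1 to compound 2 (within the scatter) is small. Compound 3 `COCCNc1nc(C)cc2c1c(N)nn2C` carries a different core; how the two cores differ is not broken down here. In this assay compound 3 gives -4%, which sits within the scatter of the value of compound 1 and beyond the scatter below the value of compound 2.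

Compound 4 `COCCNc1nc(-c2ccccc2)cc2c1c(N)nn2C` is not yet measured. It differs from compound 3 by phenyl in place of methyl on an aromatic carbon. This is the same kind of change as that from compound 1 to compound 2, but the surroundings of the place are not identical: in compound 3 the position is meta to a (2-methoxyethyl)amino group (5 heavy atoms), whereas in compound 1 it is meta to a group of 1 heavy atom. The change has been seen only once among the measured compounds.

For compound 4 the expected step is a number 6 percentage points higher from compound 3 to compound 4 (within the scatter), resting on the step of a number 6 percentage points higher from compound 1 to compound 2 (within the scatter) seen for the same kind of change on the other core, which lay within the scatter. With the measured value of compound 3 as the starting point, compound 4 is estimated to give 2% in this assay, expected to fall between -8% and 12%.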

Compound 4, a percentage reported as inhibition, at one concentration (the size of the read-out at that concentration, not a potency): -3%
Compound 4: middle estimate off by 5 percentage points, on the high side; low and high end bracket the measured number.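

Phenyl in place of methyl on an aromatic carbon gives a number 1 percentage points higher from compound 3 to compound 4 (within the scatter) in this assay, so the change again produces no step that stands out from the scatter. Set side by side, the two steps do not differ: the same change on two cores in this assay, a number 6 percentage points higher (within the scatter) from compound 1 to compound 2 and a number 1 percentage points higher (within the scatter) from compound 3 to compound 4, 5 percentage points apart, within the scatter of two such steps. This supports only a limited reading: on both cores shown, the change leaves the read-out within the scatter, but two pairs cannot show that a step of any particular size carries from one core to another, or that the same would hold on a core with clearly higher inhibition.

Open, from the compounds shown here alone, is whether an amine, a carboxylic acid or a longer alkyl chain on this aromatic carbon would move the number beyond the scatter in this assay on either core. Also open, going by these compounds, is whether replacing the (2-methoxyethyl)amino group with a piperidine or a simple primary amine would change the outcome of the phenyl for methyl exchange, and whether the picture from a single tested concentration would hold in a full measure of potency.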